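Methyl on the second aryl of the shared core

The source may report more compounds than this note shows. Statements on the series, on what has been measured and on what is new or still open speak of the compounds shown alone.

Measured compounds in a functional assay on MGC-803 cells (Homo sapiens) for inhibition, read by MTT assay, with a stated time of 72 h; a lower number here means a stronger inhibitor, a higher number a weaker inhibitor:
- compound 1 `COc1ccc(Nc2nc(SCc3cn(Cc4ccccc4Cl)nn3)nc(-c3ccccc3)c2C#N)cc1`: 7560 nM
- compound 2 `N#Cc1c(Nc2cccc(C(F)(F)F)c2)nc(SCc2cn(Cc3ccccc3Cl)nn2)nc1-c1ccccc1`: 22800 nM
- compound 3 `Cc1ccc(Nc2nc(SCc3cn(Cc4ccccc4Cl)nn3)nc(-c3ccccc3)c2C#N)cc1`: 7190 nM

Compound 3 gives the lowest number of the three, but its gap to compound 1 is within the scatter, so the two cannot be ordered. Among the measured compounds shown here, the only step beyond the scatter is at the aryl on the ring nitrogen: a 3.0-fold higher number from compound 1 to compound 2 (0.48 log units; beyond the scatter) and, read back, a 3.2-fold lower number from compound 2 to compound 3 (0.50 log units; beyond the scatter). The exchange of methoxy for methyl there, a 1.1-fold lower number from compound 1 to compound 3 (0.02 log units; within the scatter), is within the scatter.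

Compound 4 `Cc1ccc(Nc2nc(SCc3cn(Cc4ccccc4Cl)nn3)nc(-c3ccc(C)cc3)c2C#N)cc1` differs from compound 3 by methyl in place of hydrogen on an aromatic carbon. For the measured compounds named here, this is a change on the other aryl, the one attached directly to the core, and none of the measured steps touches that ring. Going by the values given here, the nearest precedent is the methoxy-to-methyl exchange between compound 1 and compound 3, which changed nothing beyond the scatter. No direction is therefore expected for a 1.0-fold higher number from compound 3 to compound 4 (0.00 log units; within the scatter), and compound 4 is estimated to give 7200 nM in this assay, with a range from 3500 nM to 15000 nM.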

Compound 4, half-maximal inhibitory concentration: 24400 nM
The estimate for compound 4 lay 3.4-fold (0.53 log units) below the measured number, and the stated range ends below it.
By their numbers in this assay, from the lowest: compounds 3 and 1 (each within the scatter of the next); then compounds 2 and 4 (each within the scatter of the next).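

In this assay, the aryl attached directly to the core responds to a single added methyl, with phenyl to 4-methylphenyl giving a 3.4-fold higher number from compound 3 to compound 4 (0.53 log units; beyond the scatter). The earlier compounds shown here showed only changes on the aryl on the ring nitrogen, where methyl and methoxy could not be told apart, so that tolerance does not carry over to this ring, where a methyl para to a large group is enough to move the number beyond the scatter. Nothing at hand explains this step.

From the compounds shown here alone, it remains open whether the step belongs to methyl alone or to any group at this place on the ring, as fluorine, a hydroxyl, an amine or a carboxylic acid there would show. Also open, going by these compounds, is whether the step holds with other aryls on the ring nitrogen.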